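Swapping a Bromophenyl Amide for a Methylphenyl Amide

The source may hold more compounds than are shown below. What is called first, only, known or untested is meant among the compounds shown, and "the series" means these compounds.

Compound 1 `COc1cc2c(cc1OC)C(CC(=O)Nc1ccc(Cl)cc1)CC2`: 60.9%
Compound 2 `COc1cc2c(cc1OC)C(CC(=O)Nc1ccc(Br)cc1)CC2`: 40.6%

Both were tested in a functional assay on the whole organism (strain Wistar) for inhibition, with Rattus norvegicus as the target, read by paw edema, with a stated time of 4 h, at a dose of 100 mg/kg; on this read-out higher numbers stand for more inhibition at the one dose given (going by the name of the read-out) and lower numbers for less inhibition. Compound 2 stands lowest of the two numbers, the step of a number 20.3 percentage points lower from compound 1 to compound 2 (beyond the scatter) lying beyond the scatter. Compound 3 `COc1cc2c(cc1OC)C(CC(=O)Nc1ccccc1C)CC2` differs from compound 2 by 2-methylphenyl in place of 4-bromophenyl on an amide-type nitrogen. Among the measured compounds shown here, no measured step covers this change; the only step known, bromo in place of chloro on an aromatic carbon, shows that a change at this end of the molecule can shift the read-out modestly. A step of roughly that size is expected, as a number 9.4 percentage points higher from compound 2 to compound 3 (within the scatter), with the direction uncertain. Compound 3 is estimated at 50%, between 30% and 70%.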

Compound 3, a percentage reported as inhibition, in the whole organism at one dose (the size of the read-out at that dose, not a potency): 25%
Estimate against measurement, compound 3: 25 percentage points above; measured number below the stated range.
By their numbers in this assay, from the lowest: compound 3; then compound 2; then compound 1.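

Putting 2-methylphenyl on the amide-type nitrogen gives less inhibition than either halogen-bearing ring, with a number 15.6 percentage points lower from compound 2 to compound 3 (beyond the scatter) and a number 35.9 percentage points lower from compound 1 to compound 3 (beyond the scatter). So a halogen is not the only change at this end that moves the read-out, and compound 3 is the lowest of the three. Because this swap alters both the substituent and its place on the ring, the two cannot be separated here, and nothing available explains the drop.

Still open, as far as these compounds go, is how 4-methylphenyl or unsubstituted phenyl would read at this nitrogen. From the compounds shown here alone, a ring carrying an amine or a carboxylic acid is equally open.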